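The compounds below may be only part of what the source reports. "The series", "measured", "known", "first", "only" and "open" are said of these compounds alone.

Three esters of the shared core are in hand: compound 1 `Cc1nc(C)c(C(=O)Oc2ccccc2/C=C/C(=O)O)nc1C`, compound 2 `COc1ccc(OC(=O)c2nc(C)c(C)nc2C)c(/C=C/C(=O)O)c1` and compound 3 `COc1ccc(/C=C/C(=O)O)cc1OC(=O)c1nc(C)c(C)nc1C`. In a functional assay on EA.hy 926 cells (Homo sapiens) for cytotoxicity, read by MTT assay, with stated times of 24 h and 12 h, tested at 12.5 uM (on this read-out higher numbers stand for a stronger effect at the one concentration tested and lower numbers for a weaker effect), compound 1 gives 45.7%, compound 2 gives 21.7% and compound 3 gives 41.3%. One change is counted between compound 2 and compound 1, (hydrogen in place of methoxy on an aromatic carbon), and it made a number 24 percentage points higher from compound 2 to compound 1 (beyond the scatter). The difference between the cores of compound 2 and compound 3 is not broken down here; their numbers stand apart beyond the scatter, whereas compound 3 and compound 1 lie within the scatter of each other. Compound 4 `Cc1nc(C)c(C(=O)Oc2cccc(/C=C/C(=O)O)c2)nc1C` is not yet measured; it is reached from compound 3 by hydrogen in place of methoxy on an aromatic carbon, the same kind of change as before, though here the place is ortho to a large group and para to the 2-carboxyethenyl group rather than meta to it and para to the large group. Beside the earlier step, a smaller rise is expected from compound 3, a number 13.7 percentage points higher from compound 3 to compound 4 (beyond the scatter), because compound 3 already starts at 41.3% and the surroundings of the place are not the same. Compound 4 is therefore estimated at 55%, between 40% and 70%.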

Compound 4, a percentage reported as activity, at one concentration (the size of the read-out at that concentration, not a potency): 61.6%
Compound 4: middle estimate off by 6.6 percentage points, on the low side; the measured number falls inside the stated range.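

In this assay, hydrogen in place of methoxy gave a number 20.3 percentage points higher from compound 3 to compound 4 (beyond the scatter), and the size of the step carried from one core to the other: the same change on two cores in this assay, a number 24 percentage points higher (beyond the scatter) from compound 2 to compound 1 and a number 20.3 percentage points higher (beyond the scatter) from compound 3 to compound 4, 3.7 percentage points apart, within the scatter of two such steps

Among these compounds, this agreement rests on only two pairs, with the methoxy at a different place in each, so it supports transfer between these two cores and no further. It gives no reason for the rise, and as a read-out at one concentration it says nothing about potency.

Still open, as far as these compounds go, is how other groups at these places, such as a hydroxyl, a chlorine or an amine, would compare with hydrogen and methoxy. Also open, from the compounds shown here alone, is whether the step would hold with an amide in place of the ester link.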